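Replacing (phenylsulfonyl)amino with 4-chlorophenyl on a shared core

This account rests on a few compounds, and the source may have more. Where it says the series, first, only, none or still open, it means among the compounds named here.

Compound 1 (`O=C1Nc2ccc(S(=O)(=O)N3CCOCC3)cc2/C1=N/c1cccc(C(F)(F)F)c1`): 226000 nM
Compound 2 (`O=C1Nc2ccc(S(=O)(=O)N3CCOCC3)cc2/C1=N/NS(=O)(=O)c1ccccc1`): 302000 nM

Both compounds were tested in an ADME assay on WI-38 cells (Homo sapiens) for cytotoxicity, read by sulforhodamine B assay, with a stated time of 24 h (a higher number here means a weaker inhibitor, a lower number a stronger inhibitor), and these two numbers are all that exist so far. Compound 2 (302000 nM) sits within the scatter of compound 1 (226000 nM) and the two cannot be ranked. Scatter here means the ordinary spread between repeat measurements.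

Compound 3 (`O=C1Nc2ccc(S(=O)(=O)N3CCOCC3)cc2/C1=N/c1ccc(Cl)cc1`) differs from compound 2 in one place (4-chlorophenyl in place of (phenylsulfonyl)amino on a double-bonded nitrogen), with 4-chlorophenyl in place of (phenylsulfonyl)amino on a double-bonded nitrogen. Among the compounds with values here, no measured compound carries 4-chlorophenyl. One measured step still bears on this change, since compound 1 also has a substituted phenyl ring on that nitrogen, namely 3-(trifluoromethyl)phenyl. That step is a 1.3-fold higher number from compound 1 to compound 2 (0.13 log units; within the scatter) and it stays within the scatter, so a small change is the reasonable expectation, with no firm direction. In this assay the expected step is a 1.3-fold lower number from compound 2 to compound 3 (0.10 log units; within the scatter) and it would also stay within the scatter. The estimated value for compound 3 is 240000 nM (expected range 110000 nM to 480000 nM).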

Compound 3, half-maximal inhibitory concentration: 468000 nM
Compound 3: the middle estimate sits 2.0-fold (0.29 log units) below what was measured; low and high end bracket the measured number.
By their numbers in this assay, from the lowest: compounds 1, 2 and 3 (each within the scatter of the next, the first and the last beyond it).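

In this assay, putting 4-chlorophenyl on the double-bonded nitrogen in place of (phenylsulfonyl)amino gives a 1.5-fold higher number from compound 2 to compound 3 (0.19 log units; within the scatter), so this exchange, which removes a hydrogen-bond donor and two hydrogen-bond acceptors, produces no difference that can be told apart from ordinary repeat variation. Within the data shown here, the only step at this position that clears the scatter is between two substituted phenyl rings: 4-chlorophenyl in place of 3-(trifluoromethyl)phenyl gives a 2.1-fold higher number from compound 1 to compound 3 (0.32 log units; beyond the scatter), a modest shift towards weaker inhibition, which shows that changing the substituted phenyl ring alone can move the number slightly more than replacing the ring-bearing sulfonyl group does. Nothing available explains this small shift.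

Compound 1 and compound 3 differ in both the ring substituent and where it sits, so the compounds shown cannot tell whether the substituent or its location matters more. Also open, from the compounds shown here alone, is how this assay would respond to a phenyl ring carrying an amine or a carboxylic acid, or to a longer alkyl chain on the same nitrogen.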